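The compounds below may be only part of what the source reports. "The series", "measured", "known", "first", "only" and "open" are said of these compounds alone.

Compound 1 `CCCCNC(=O)c1c(O)c2cccnc2n(-c2ccccc2)c1=O`: 12.8% in a functional assay on the whole organism for inhibition, with Rattus norvegicus as the target, read by paw edema, at a dose of 100 mg/kg by the oral route; on this read-out higher numbers stand for more inhibition at the one dose given (going by the name of the read-out) and lower numbers for less inhibition
Compound 2 `O=C(NCc1ccccc1)c1c(O)c2cccnc2n(-c2ccccc2)c1=O`: 1.6%
Compound 3 `O=C(Nc1cccc(Cl)c1)c1c(O)c2cccnc2n(-c2ccccc2)c1=O`: 7.6%

Compound 1 shows the highest of the three numbers in this assay; compound 3 sits within the scatter of it a number 5.2 percentage points lower from compound 1 to compound 3 (within the scatter), while compound 2 lies beyond it a number 11.2 percentage points lower from compound 1 to compound 2 (beyond the scatter). Compound 4 `COc1ccccc1NC(=O)c1c(O)c2cccnc2n(-c2ccccc2)c1=O` differs from compound 1 in one place: 2-methoxyphenyl in place of butyl on an amide-type nitrogen. For the measured compounds named here, the closest precedent is the move from compound 1 to compound 3, where an aromatic ring replaced the butyl on the same amide-type nitrogen and gave a number 5.2 percentage points lower from compound 1 to compound 3 (within the scatter); between the two aromatic amides the change was a number 6 percentage points higher from compound 2 to compound 3 (within the scatter), also within the scatter. A small downward step or none beyond the scatter is therefore expected, a number 4.8 percentage points lower from compound 1 to compound 4 (within the scatter). Compound 4 is estimated at 8%, expected to fall between 0% and 20%.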

Compound 4, a percentage reported as inhibition, in the whole organism at one dose (the size of the read-out at that dose, not a potency): 8.1%
For compound 4 the middle estimate is 0.1 percentage points below the measured one; measured number inside the range.
By their numbers in this assay, from the lowest: compounds 2, 3, 4 and 1 (each within the scatter of the next, the first and the last beyond it).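

In this assay, 2-methoxyphenyl on the amide-type nitrogen gives a result that cannot be separated from that of 3-chlorophenyl: a number 0.5 percentage points higher from compound 3 to compound 4 (within the scatter). Set against the other two amides, the changes are a number 4.7 percentage points lower from compound 1 to compound 4 (within the scatter) and a number 6.5 percentage points higher from compound 2 to compound 4 (within the scatter), so compound 4 stays within the scatter of compound 1 and compound 2, even though those two lie beyond the scatter of each other. No measurement here accounts for these small differences.

As far as these compounds go, whether a longer chain than butyl, or a chain ending in an amine, on this nitrogen would give a number beyond the scatter of compound 1 remains open.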